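This account rests on a few compounds, and the source may have more. Where it says the series, first, only, none or still open, it means among the compounds named here.

In an ADME assay on LLC-MK2 cells (Macaca mulatta) for cytotoxicity, read by spectrophotometry and crystal violet staining, with a stated time of 4 days (on this read-out lower numbers stand for higher toxicity in this test and higher numbers for lower toxicity in this test), compound 1 `CC(C)n1ncc2c(C(=O)Nc3c(F)cccc3F)cc(-c3cccs3)nc21` gives > 200000 nM as a limit of the assay and not a number. Compound 2 `CC(C)n1ncc2c(C(=O)Nc3ccc(F)cc3F)cc(-c3cccs3)nc21` gives > 200000 nM and this too is only a limit. The evidence so far is the limit of > 200000 nM in this assay, at which 2 of the 2 values shown sit, and nothing more. Among the measured compounds shown here, the one measured step, a step that the two limits leave unreadable from compound 1 to compound 2, has no readable size. Compound 3 `CC(C)n1ncc2c(C(=O)Nc3cncnc3)cc(-c3cccs3)nc21` carries the change pyrimidin-5-yl in place of 2,4-difluorophenyl on an amide-type nitrogen with pyrimidin-5-yl in place of 2,4-difluorophenyl on the amide-type nitrogen. For the measured compounds named here, no measured step gives a size for this change, so no step beyond the scatter is expected in this assay and no direction is favoured. The expected step is a number no higher from compound 2 to compound 3 (the limit leaves the size open) in size. Compound 3 is estimated at 200000 nM within a range from 100000 nM to 400000 nM and this expected value may turn out to be only a limit.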

Compound 3, half-maximal cytotoxic concentration: 20000 nM
The estimate for compound 3 lay 10-fold (1.00 log units) above the measured number; measured number below the stated range.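

In this assay the group on the amide-type nitrogen matters: pyrimidin-5-yl in place of 2,4-difluorophenyl moves the read-out (an at least 10-fold lower number from compound 2 to compound 3 (1.00 log units; beyond the scatter)), and pyrimidin-5-yl in place of 2,6-difluorophenyl does the same (an at least 10-fold lower number from compound 1 to compound 3 (1.00 log units; beyond the scatter)). Compound 3 is the only compound shown with a number rather than a limit, so this position can shift the series toward higher toxicity in this test. The full size of both steps stays open because the two difluorophenyl compounds rest on a limit: the limit of > 200000 nM in this assay, at which 2 of the 3 values shown sit.

Where a plain phenyl or a pyridin-3-yl on the same nitrogen would fall remains open. The compounds shown also leave open whether an aliphatic amine-bearing group there would give a number or a limit.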